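A Second Methoxy Group and Where It Sits

This account rests on a few compounds, and the source may have more. Where it says the series, first, only, none or still open, it means among the compounds named here.

Measured so far in a functional assay on FaDu cells (Homo sapiens) for cytotoxicity, read by MTT assay, with a stated time of 72 h; a lower number here means that less compound is tolerated, a higher number that more compound is tolerated:
compound 1, `COc1ccc(NC(=O)C(=O)c2cn(C(C)C)c3ccccc23)cc1`: 181 nM
compound 2, `COc1ccc(NC(=O)C(=O)c2cn(C(C)C)c3cccc(OC)c23)cn1`: 7780 nM
compound 3, `COc1ccc(NC(=O)C(=O)c2cn(C(C)C)c3ccccc23)cn1`: 85 nM

Compound 1 and compound 3 share a core and differ only in the group on the amide-type nitrogen. How the two cores differ is shown here (4-methoxyphenyl in place of 6-methoxypyridin-3-yl on an amide-type nitrogen), and the step is a 2.1-fold lower number from compound 1 to compound 3 (0.33 log units; beyond the scatter), a modest one. Compound 2 carries one further methoxy group on the core of compound 3 (methoxy in place of hydrogen on an aromatic carbon), and this single addition made the large step of a 92-fold higher number from compound 3 to compound 2 (1.96 log units; beyond the scatter).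

Compound 4, `COc1ccc(NC(=O)C(=O)c2cn(C(C)C)c3ccccc23)cc1OC`, has not yet been measured in this assay. It differs from compound 1 by the same kind of change (methoxy in place of hydrogen on an aromatic carbon), but the place is not the same: in compound 2 the entering methoxy sits on a six-membered aromatic ring that is part of a fused or bridged system of two rings, ortho and meta to a fused ring, whereas in compound 4 it sits on a six-membered aromatic ring of carbon only, ortho to a methoxy group and meta to a large group.

Because the earlier step of a 92-fold higher number from compound 3 to compound 2 (1.96 log units; beyond the scatter) was large, an increase from compound 1 to compound 4 is expected, but because the place differs, a smaller step is expected, a 3.3-fold higher number from compound 1 to compound 4 (0.52 log units; beyond the scatter). Compound 4 is estimated at 600 nM, likely between 120 nM and 3000 nM.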

Compound 4, concentration lethal to 50% of the cells: > 10000 nM
Compound 4 was reported as a limit; the forecaster's own chance of this, stated with the estimate: 5%; at least 16-fold (1.22 log units) between middle value and limit.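

In this assay compound 4 gives > 10000 nM, which is a limit of the assay and not a number. Even read as a limit, the entering methoxy group produced a large change: the result is an at least 55-fold higher number from compound 1 to compound 4 (1.74 log units; beyond the scatter). Compound 2 and compound 4 therefore show the same direction for this change on two different cores, even though the methoxy group enters a different place in each, but two pairs do not make a rule for the series, and they do not show that a methoxy group raises the number wherever it is placed. Nor can the size of the step be said to carry over unchanged, and the comparison stops at this point: the same change on two cores in this assay, a 92-fold higher number (1.96 log units; beyond the scatter) from compound 3 to compound 2 and an at least 55-fold higher number (1.74 log units; beyond the scatter) from compound 1 to compound 4; the limit leaves it open whether they differ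

The compounds shown leave open whether the effect belongs to methoxy itself or would also appear with another group at these two places, such as a hydroxy group, a fluorine atom or a longer chain like ethoxy. They also leave open what a methoxy group would do at other places on the shared core, and whether an amine there would follow the same direction.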